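Heteroaryl swaps on the shared core: series notes

The compounds below may be only part of what the source reports. "The series", "measured", "known", "first", "only" and "open" are said of these compounds alone.

Compound 1 `COc1cc2nc(N3CCN(c4ccncn4)CC3)nc(N)c2cc1OC` gives 0.27 nM in an assay on brain for binding affinity to Adrenergic receptor alpha-1 (Rattus norvegicus); on this read-out lower numbers stand for stronger inhibition and higher numbers for weaker inhibition.
Compound 2 `COc1cc2nc(N3CCN(c4cccnn4)CC3)nc(N)c2cc1OC` gives 0.4 nM.
Compound 3 `CCCOc1ccnc(N2CCN(c3nc(N)c4cc(OC)c(OC)cc4n3)CC2)n1` gives 0.32 nM.

Compound 3 stands second highest of the three numbers, with compound 1 nearest and compound 2 furthest; neither gap exceeds the scatter, so the three compounds cannot be ordered.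

Compound 4 `COc1cc2nc(N3CCN(c4nccc(C)n4)CC3)nc(N)c2cc1OC` differs from compound 3 in one place: methyl in place of propoxy on an aromatic carbon. Within the data shown here, no measured step alters this group directly. Among the measured compounds shown here, the steps that bear on it replace the whole heteroaryl on the ring nitrogen: a 1.2-fold higher number from compound 1 to compound 3 (0.07 log units; within the scatter), a 1.3-fold lower number from compound 2 to compound 3 (0.10 log units; within the scatter) and a 1.5-fold higher number from compound 1 to compound 2 (0.17 log units; within the scatter). Each of these larger swaps stayed within the scatter, which suggests the group on the ring nitrogen tolerates change without a clear shift in the number.

On that basis a smaller exchange on the same ring is expected to give no step beyond the scatter, so compound 4 is expected at a 1.1-fold lower number from compound 3 to compound 4 (0.03 log units; within the scatter). For compound 4 the estimate is 0.3 nM, with an expected range from 0.12 nM to 0.8 nM.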

Compound 4, inhibition constant: 0.92 nM
Compound 4: the middle estimate sits 3.1-fold (0.49 log units) below what was measured; measured number outside the range, above it.
By their numbers in this assay, from the lowest: compounds 1, 3 and 2 (each within the scatter of the next); then compound 4.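

Among these compounds, the exchange of 4-propoxypyrimidin-2-yl for 4-methylpyrimidin-2-yl gives the first step to pass the scatter in this assay (a 2.9-fold higher number from compound 3 to compound 4 (0.46 log units; beyond the scatter)), so the group at this position on the ring does affect the number. The two steps from the other heteroaryls point the same way (a 2.3-fold higher number from compound 2 to compound 4 (0.36 log units; beyond the scatter); a 3.4-fold higher number from compound 1 to compound 4 (0.53 log units; beyond the scatter)), which limits the tolerance suggested by compound 1, compound 2 and compound 3 to those three groups and does not extend it to 4-methylpyrimidin-2-yl. Nothing available explains the shift.

From the compounds shown here alone, with only propoxy and methyl compared here, it remains open whether the number follows the length of the chain or the presence of the ether oxygen. Ethoxy, a longer alkyl chain or an amine at this position would help separate these readings.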